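Cytotoxicity limits ahead of the dimethylamino compound

This account rests on a few compounds, and the source may have more. Where it says the series, first, only, none or still open, it means among the compounds named here.

Values in an ADME assay on HEK293 cells (Homo sapiens) for cytotoxicity, with a stated time of 6 h; on this read-out lower numbers stand for higher toxicity in this test and higher numbers for lower toxicity in this test:
compound 1 `CNc1nc(N)nc2ccccc12`: > 25000 nM
compound 2 `CCCC(C)Nc1nc(N)nc2ccccc12`: > 25000 nM
compound 3 `CCCCNc1nc(N)nc2cc(CO)ccc12`: > 18000 nM

All three entries are limits and not numbers. Compound 3 stands only as a limit, (the limit of > 18000 nM in this assay, at which 1 of the 3 values shown sits). Compound 1 and compound 2 share another limit, (the limit of > 25000 nM in this assay, at which 2 of the 3 values shown sit). Going by the values given here, no compound yet has a readable half-maximal cytotoxic concentration.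

Compound 4 `CCCCNc1nc(N)nc2cc(CN(C)C)ccc12` differs from compound 3 by one change: dimethylamino in place of hydroxy on a saturated chain carbon bound to an aromatic carbon. Cut one bond further out, this reads hydroxymethyl to (dimethylamino)methyl.

Among the compounds with values here, only one measured step exists, a step that the two limits leave unreadable from compound 1 to compound 2. It has no readable size and lies at a different place, on a nitrogen on an aromatic ring, so it gives no size for this change. Within the data shown here, no measured step touches the hydroxy group. The expectation therefore rests on compound 3, whose limit is > 18000 nM.

No direction can be argued in this assay, and no shift beyond the scatter is expected. The estimated step is a step that the limit leaves unreadable from compound 3 to compound 4. Compound 4 is estimated at 22000 nM, with an expected range from 9000 nM to 50000 nM.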

Compound 4, half-maximal cytotoxic concentration: > 18000 nM
Compound 4: a limit, no number; the forecaster's own chance of this, stated with the estimate: 65%; the middle value lies beyond the limit too.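

In this assay, compound 3 and compound 4 are both limits and not numbers, so no step can be read for dimethylamino in place of hydroxy. Both stand at the same limit: the limit of > 18000 nM in this assay, at which 2 of the 4 values shown sit.

The compounds shown leave open whether any member of this series reaches a readable half-maximal cytotoxic concentration in this assay.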